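Changing the group on the nitrogen of the shared core

The compounds below may be only part of what the source reports. "The series", "measured", "known", "first", "only" and "open" are said of these compounds alone.

Compound 1 `CSc1nc(NC2CC2)c2cccnc2n1`: 4900 nM
Compound 2 `CCC(CC)Nc1nc(SC)nc2ncccc12`: 2720 nM

For the measured compounds named here, in a functional assay (Nicotiana tabacum) (a higher number here means a weaker inhibitor, a lower number a stronger inhibitor), compound 2 reads 2720 nM, and its only measured neighbour, compound 1, lies within the scatter of it. Compound 3 `CSc1nc(Nc2ccccc2)c2cccnc2n1` is still unmeasured. The change to it from compound 2 is phenyl in place of pentan-3-yl on a nitrogen on an aromatic ring.

Going by the values given here, one measured step bears on this place: a 1.8-fold lower number from compound 1 to compound 2 (0.26 log units; within the scatter), with pentan-3-yl in place of cyclopropyl on the same nitrogen. That step did not leave the scatter. Among the compounds with values here, it is also the only evidence available, as no measured compound carries phenyl on this nitrogen, and a single step gives no direction for a new kind of group. With only a 1.8-fold lower number from compound 1 to compound 2 (0.26 log units; within the scatter) to go on, the step expected in this assay is a 1.1-fold higher number from compound 2 to compound 3 (0.04 log units; within the scatter), so no shift beyond the scatter is expected, though the uncertainty is wide. For compound 3 the estimated value is 3000 nM, with an expected range of 900 nM to 10000 nM.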

Compound 3, half-maximal inhibitory concentration: 15900 nM
Compound 3: middle estimate off by 5.3-fold (0.72 log units), on the low side; measured number above the stated range.
By their numbers in this assay, from the lowest: compounds 2 and 1 (each within the scatter of the next); then compound 3.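

Working notes on the nitrogen substituent: in this assay this position does respond to the group it carries, with a 5.8-fold higher number from compound 2 to compound 3 (0.77 log units; beyond the scatter) and a 3.2-fold higher number from compound 1 to compound 3 (0.51 log units; beyond the scatter), both beyond the scatter, whereas the earlier step between the two compounds without phenyl stayed within it. For the compounds shown here, compound 3 is the weakest inhibitor of the three, so within this small set phenyl is the one group that separates from the others, while pentan-3-yl and cyclopropyl cannot be told apart. No supporting data accompany these numbers, so the shift seen with phenyl remains an observation without an explanation.

Going by these compounds, it remains open whether the higher number goes with any aromatic ring on this nitrogen or only with unsubstituted phenyl, a question that benzyl, pyridyl or methoxyphenyl groups would help to settle. Equally open, on these data alone, is how far the non-aromatic side extends, since a cyclohexyl group or a longer alkyl chain on the same nitrogen could either stay level with compound 2 or depart from it.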